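The source may report more compounds than this note shows. Statements on the series, on what has been measured and on what is new or still open speak of the compounds shown alone.

Working notes on the side-chain variation. Compound 1 `COc1nc(C)c(Nc2nc(Cl)cn([C@H](COC(=O)c3ccccc3)C3CC3)c2=O)cc1C` and compound 2 `COc1nc(C)c(Nc2nc(Cl)cn([C@H](COC(=O)c3ccccn3)C3CC3)c2=O)cc1C` share the same core and differ only in the group on the carbonyl carbon. In an assay on frontal cortex for displacement of a labelled ligand from corticotropin-releasing factor receptor 1 (Rattus norvegicus), with a stated time of 2 h (on this read-out lower numbers stand for stronger inhibition and higher numbers for weaker inhibition), compound 1 gives 1.5 nM, while compound 2 gives 67 nM. Among the compounds with values here, the one measured step, a 45-fold higher number from compound 1 to compound 2 (1.65 log units; beyond the scatter), leaves compound 2 standing at the highest of the two numbers, with compound 1 as the nearest neighbour at a far lower number.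

Compound 3 `COc1ccc(NC(=O)OC[C@H](C2CC2)n2cc(Cl)nc(Nc3cc(C)c(OC)nc3C)c2=O)c(C)n1` is the next variant: (6-methoxy-2-methylpyridin-3-yl)amino in place of pyridin-2-yl on a carbonyl carbon. Within the data shown here, the change sits on the same carbonyl carbon as the measured step, but the entering group differs from either group in that step, so no measured step bears on it directly. What the step of a 45-fold higher number from compound 1 to compound 2 (1.65 log units; beyond the scatter) does show is that this part of the molecule can move the read-out by a large amount, so a wide range has to be allowed. The step from compound 2 to compound 3 is expected to be a 2.2-fold lower number from compound 2 to compound 3 (0.35 log units; beyond the scatter), leaning toward a lower number but with low confidence. Compound 3 is estimated at 30 nM, with a range from 5 nM to 200 nM.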

Compound 3, half-maximal inhibitory concentration: 9.2 nM
The estimate for compound 3 lay 3.3-fold (0.51 log units) above the measured number; the measured number falls inside the stated range.
By their numbers in this assay, from the lowest: compound 1; then compound 3; then compound 2.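

In this assay, (6-methoxy-2-methylpyridin-3-yl)amino on the carbonyl carbon gives a 7.3-fold lower number from compound 2 to compound 3 (0.86 log units; beyond the scatter), so a pyridine ring in this part of the side chain does not by itself fix the read-out at the level of pyridin-2-yl; the entering group also holds one six-membered aromatic ring with 1 hetero atom, yet the number differs well beyond the scatter. Set against phenyl, the same group gives a 6.1-fold higher number from compound 1 to compound 3 (0.79 log units; beyond the scatter), so phenyl keeps the lowest number of the three groups, and the larger group recovers only part of the gap opened by pyridin-2-yl. Nothing at hand accounts for either step.

The change to compound 3 brings the amino link, the methoxy group and the methyl group together, so the compounds shown do not separate what each contributes to the step. Going by these compounds, how a plain phenylamino group, or a saturated amine such as morpholine, would read on the same carbonyl carbon in this assay stays open, as does whether any group here can match phenyl.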